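This account rests on a few compounds, and the source may have more. Where it says the series, first, only, none or still open, it means among the compounds named here.

Working notes on the series in a functional assay for inhibition of sodium/hydrogen exchanger (Oryctolagus cuniculus); a lower number here means a stronger inhibitor, a higher number a weaker inhibitor. Compound 1 `Cc1cc(-c2ccc(Cl)cc2Cl)c(S(C)(=O)=O)cc1C(=O)N=C(N)N` gives 42 nM in this assay. Compound 2 `Cc1cc(Sc2ccccc2Cl)c(S(C)(=O)=O)cc1C(=O)N=C(N)N` gives 14 nM and compound 3 `Cc1cc(Sc2ccc(Cl)cc2)c(S(C)(=O)=O)cc1C(=O)N=C(N)N` gives 19 nM. Compound 3 thus holds the second highest of the three numbers, nearest to compound 2 and furthest from compound 1. The measured steps are a 3.0-fold lower number from compound 1 to compound 2 (0.48 log units; beyond the scatter) and a 2.2-fold lower number from compound 1 to compound 3 (0.34 log units; beyond the scatter), both beyond the scatter, and a 1.4-fold higher number from compound 2 to compound 3 (0.13 log units; within the scatter), which stays within it.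

The step to compound 4 `Cc1cc(-n2cccn2)c(S(C)(=O)=O)cc1C(=O)N=C(N)N` is 1H-pyrazol-1-yl in place of (4-chlorophenyl)sulfanyl on an aromatic carbon. Going by the values given here, none of the measured steps bears directly on it: all three keep a six-membered aromatic ring of carbon only at this position, with or without the sulfur, and differ from one another only modestly. Among the compounds with values here, the move to a five-membered aromatic ring with 2 hetero atoms, and from 8 heavy atoms to 5, has no precedent here. Within the data shown here, the guidance is only that changes at this position have so far shifted the number by no more than the step of a 3.0-fold lower number from compound 1 to compound 2 (0.48 log units; beyond the scatter). From the compounds shown here alone, a step of modest size is expected, more likely toward a higher number, but either direction remains open.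

For compound 4 the expected result in this assay is 45 nM, with a range of 15 nM to 140 nM, which corresponds to an expected step of a 2.4-fold higher number from compound 3 to compound 4 (0.37 log units; beyond the scatter).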

Compound 4, half-maximal inhibitory concentration: 25 nM
Estimate against measurement, compound 4: 1.8-fold (0.26 log units) above, and the stated range covers the measured number.
By their numbers in this assay, from the lowest: compounds 2, 3, 4 and 1 (each within the scatter of the next, the first and the last beyond it).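

In this assay, a 1.3-fold higher number from compound 3 to compound 4 (0.12 log units; within the scatter) and a 1.8-fold higher number from compound 2 to compound 4 (0.25 log units; within the scatter) and also a 1.7-fold lower number from compound 1 to compound 4 (0.23 log units; within the scatter) all stay within the scatter, so 1H-pyrazol-1-yl, with 5 heavy atoms, gives a number that cannot be told apart from those of the three earlier compounds. The earlier compounds shown here all carried a six-membered aromatic ring of carbon only with a chlorine on it, so they could not show that this aromatic carbon, ortho to a methylsulfonyl group, also takes a five-membered aromatic ring with 2 hetero atoms, without chlorine or sulfur, and stays in the same range of numbers. No measurement at hand accounts for this result.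

From the compounds shown here alone, whether the range holds for a group without an aromatic ring at this carbon, such as an amine, morpholine or a short alkoxy chain, stays open. Also open, going by these compounds, is how a methyl group or a carboxylic acid on the pyrazole ring, or an isomeric imidazol-1-yl ring in its place, would move the number.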